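A few compounds are considered here, and "the series" means these few. Any claim that something is new, unique, unknown or untested is made for them only; others in the source may bear on it.

Measured in an ADME assay on Vero cells (Chlorocebus sabaeus) for cytotoxicity, with a stated time of 3 days (a lower number here means a stronger inhibitor, a higher number a weaker inhibitor), every value a limit:

compound 1 `CCOC(=O)Nc1cc(N)c2[nH]c(-c3ccc(Br)cc3)nc2c1`: > 200 ug/mL
compound 2 `CCOC(=O)Nc1cc(NC(=O)C2CCCC2)c2[nH]c(-c3ccc(Br)cc3)nc2c1`: > 200 ug/mL
compound 3 `CCOC(=O)Nc1cc(NC(=O)c2ccccc2)c2[nH]c(-c3ccc(Br)cc3)nc2c1`: > 200 ug/mL

Compound 3 gives > 200 ug/mL, which is a limit and not a number. It shares that reading with the other two compounds: the limit of > 200 ug/mL in this assay, at which 3 of the 3 values shown sit.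

Compound 4 `CCOC(=O)Nc1cc(NC(=O)c2ccccc2)c2[nH]c(-c3ccc(C(=O)OC)cc3)nc2c1` differs from compound 3 in one place: methoxycarbonyl in place of bromo on an aromatic carbon. This is methoxycarbonyl in place of bromo on an aromatic carbon, or 4-bromophenyl to 4-(methoxycarbonyl)phenyl.

The measured steps are a step that the two limits leave unreadable from compound 1 to compound 2, a step that the two limits leave unreadable from compound 1 to compound 3 and a step that the two limits leave unreadable from compound 2 to compound 3. All three keep the bromo, so none of them measures this exchange directly, and none has a readable size.

The expectation therefore rests on compound 3, which reads > 200 ug/mL, a limit. The expected result is a step that the limit leaves unreadable from compound 3 to compound 4, with no change beyond the scatter in this assay and a further limit the likely report. For compound 4 the estimate is 220 ug/mL, with an expected range from 90 ug/mL to 400 ug/mL.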

Compound 4, half-maximal inhibitory concentration: 650 ug/mL
Estimate against measurement, compound 4: 3.0-fold (0.47 log units) below, and the stated range ends below it.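

Within the data shown here, no step from compound 3 to compound 4 can be read: in this assay compound 3 gives > 200 ug/mL, which is a limit. The compounds shown leave open how large the exchange of bromo for methoxycarbonyl on the shared core is in this assay.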